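This account rests on a few compounds, and the source may have more. Where it says the series, first, only, none or still open, it means among the compounds named here.

Measured so far in a functional assay on HepG2 cells (Homo sapiens) for antiproliferative activity, read by MTT assay; a higher number here means a weaker inhibitor, a lower number a stronger inhibitor:
Compound 1 `Cc1c(-n2cc(COc3ccc(/C=C/C(=O)c4cc5c(cc4O)OC(C)(C)CC5)cc3)nn2)cccc1[N+](=O)[O-]` gives 109000 nM
Compound 2 `CC1(C)CCc2c(ccc(C(=O)/C=C/c3ccc(OCc4cn(-c5ccc(Br)cc5)nn4)cc3)c2O)O1` gives 136000 nM
Compound 3 `Cc1c(-n2cc(COc3ccc(/C=C/C(=O)c4ccc5c(c4O)CCC(C)(C)O5)cc3)nn2)cccc1[N+](=O)[O-]` gives 115000 nM

These numbers all lie within the scatter of one another, so compound 3, at 115000 nM, cannot be separated from compound 1 or compound 2. Compound 4 `CCc1ccccc1-n1cc(COc2ccc(/C=C/C(=O)c3ccc4c(c3O)CCC(C)(C)O4)cc2)nn1` differs from compound 3 by one change: 2-ethylphenyl in place of 2-methyl-3-nitrophenyl on an aromatic nitrogen. Among the compounds with values here, only one measured step bears on it, an exchange on the same aromatic nitrogen, 2-methyl-3-nitrophenyl in place of 4-bromophenyl. That step, a 1.2-fold lower number from compound 2 to compound 3 (0.07 log units; within the scatter), stayed within the scatter. No step beyond the scatter is therefore expected in this assay, and the estimated step is a 1.0-fold higher number from compound 3 to compound 4 (0.02 log units; within the scatter) here. Compound 4 is expected at 120000 nM (estimated range 70000 nM to 200000 nM).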

Compound 4, half-maximal inhibitory concentration: 67800 nM
Compound 4: middle estimate off by 1.8-fold (0.25 log units), on the high side; the whole stated range lies above it.
By their numbers in this assay, from the lowest: compounds 4, 1, 3 and 2 (each within the scatter of the next).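

In this assay, replacing the group on the aromatic nitrogen gives a 1.7-fold lower number from compound 3 to compound 4 (0.23 log units; within the scatter) and a 2.0-fold lower number from compound 2 to compound 4 (0.30 log units; within the scatter). 2-Ethylphenyl, made of carbon only and with no hydrogen-bond acceptors, thus stays within the scatter of both 2-methyl-3-nitrophenyl, which has 2 hydrogen-bond acceptors, and 4-bromophenyl. Nothing measured here accounts for these values. The compounds shown leave open whether any group on this nitrogen can move the number beyond the scatter. They also leave open what an amine or a carboxylic acid on this phenyl ring would give in this assay.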